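Heteroaryl swap on the ethyl chain: exposure notes

A few compounds are considered here, and "the series" means these few. Any claim that something is new, unique, unknown or untested is made for them only; others in the source may bear on it.

Measured so far:
compound 1 `Cc1cc(SC2=C(O)OC(CCc3nccs3)(C(C)C)CC2=O)c(C(C)(C)C)cc1CO` — 2700 nM
compound 2 `Cc1cc(SC2=C(O)OC(CCc3scnc3C)(C(C)C)CC2=O)c(C(C)(C)C)cc1CO` — 770000 nM

Among the compounds with values here, in an in vivo ADME assay on the whole organism for pharmacokinetics, at a dose of 25 mg/kg by the oral route (on this read-out lower numbers stand for lower exposure and higher numbers for higher exposure at the dose given), compound 2 holds the higher of the two numbers, with compound 1 as its only neighbour; the one measured step is a 290-fold higher number from compound 1 to compound 2 (2.46 log units; beyond the scatter). Compound 3 `Cc1cc(SC2=C(O)OC(CCc3ccsc3)(C(C)C)CC2=O)c(C(C)(C)C)cc1CO` is not yet measured. Its difference from compound 2 is thiophen-3-yl in place of 4-methyl-1,3-thiazol-5-yl on a saturated chain carbon, two bonds along the chain from a saturated ring carbon. Within the data shown here, only the step from compound 1 to compound 2 bears on this change, since it alters the same heteroaryl at the same place, and that step was large, so this position clearly moves the read-out. Among the measured compounds shown here, no measured compound carries thiophen-3-yl, so the direction rests on little. Because compound 2 already gives 770000 nM, the highest number seen, a downward step is expected for compound 3, of uncertain size, a 7.7-fold lower number from compound 2 to compound 3 (0.89 log units; beyond the scatter). Compound 3 is therefore estimated at 100000 nM, within 10000 nM to 600000 nM.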

Compound 3, maximal plasma concentration: 11200000 nM
Compound 3: middle estimate off by 110-fold (2.05 log units), on the low side; the measured number lies above the stated range.
By their numbers in this assay, from the lowest: compound 1; then compound 2; then compound 3.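

In this assay, the heteroaryl on the ethyl chain had not reached its ceiling with 4-methyl-1,3-thiazol-5-yl: the change to thiophen-3-yl gives a 15-fold higher number from compound 2 to compound 3 (1.16 log units; beyond the scatter). Against 1,3-thiazol-2-yl, the same group gives a 4100-fold higher number from compound 1 to compound 3 (3.62 log units; beyond the scatter), so the order across these three compounds places the group with one hetero atom above both groups with two, although three compounds set an order and not a rule. Nothing available here accounts for that order.

Going by these compounds, it remains open whether the ring methyl or the ring itself drives the step between the two thiazoles, which 1,3-thiazol-5-yl without the methyl would separate. Also open, on these data alone, is whether the high number holds for thiophen-2-yl, phenyl or pyridin-3-yl at this place, or for a longer chain.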